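The source may report more compounds than this note shows. Statements on the series, on what has been measured and on what is new or still open speak of the compounds shown alone.

Working notes on the series. The shared core is varied at one aromatic carbon. Compound 1 `Nc1ccc(S(=O)(=O)N2CCN(c3ncc(C(O)(C(F)(F)F)C(F)(F)F)cc3Br)CC2)cn1` carries bromo there, compound 2 `CCn1cc(-c2cc(C(O)(C(F)(F)F)C(F)(F)F)cnc2N2CCN(S(=O)(=O)c3ccc(N)nc3)CC2)cn1` carries 1-ethyl-1H-pyrazol-4-yl, and compound 3 `Nc1ccc(S(=O)(=O)N2CCN(c3ncc(C(O)(C(F)(F)F)C(F)(F)F)cc3-c3ccc4scnc4c3)CC2)cn1` carries 1,3-benzothiazol-5-yl. In an ADME assay (liver) for metabolic stability, with Liver microsome (Homo sapiens) as the target, using microsomes and NADPH, with a stated time of 30 min, tested at 1 uM (a higher number here means faster removal of the compound, a lower number slower removal), compound 1 gives only a limit, < 14 mL.min-1.g-1. That reading is the limit of < 14 mL.min-1.g-1 in this assay, at which 1 of the 3 values shown sits. Compound 2 gives 20 mL.min-1.g-1 in this assay and stands lowest of the two numbers shown, while compound 3 gives 39 mL.min-1.g-1. The measured steps are an at least 1.4-fold higher number from compound 1 to compound 2 (0.15 log units; that floor lies within the scatter), an at least 2.7-fold higher number from compound 1 to compound 3 (0.44 log units; beyond the scatter) and a 2.0-fold higher number from compound 2 to compound 3 (0.29 log units; within the scatter).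

Compound 4 `Nc1ccc(S(=O)(=O)N2CCN(c3ncc(C(O)(C(F)(F)F)C(F)(F)F)cc3-c3ccc4[nH]ncc4c3)CC2)cn1` differs from compound 2 in one place: 1H-indazol-5-yl in place of 1-ethyl-1H-pyrazol-4-yl on an aromatic carbon. The step that bears most is a 2.0-fold higher number from compound 2 to compound 3 (0.29 log units; within the scatter), where a five-membered aromatic ring gave way to one joined to a six-membered aromatic ring of carbon only, as happens here too; that step stayed within the scatter. A hydrogen-bond donor enters with 1H-indazol-5-yl, which 1,3-benzothiazol-5-yl lacks. For compound 4 the expected step is a 1.4-fold higher number from compound 2 to compound 4 (0.15 log units; within the scatter), not beyond the scatter. Compound 4 is estimated at 28 mL.min-1.g-1, between 14 mL.min-1.g-1 and 55 mL.min-1.g-1.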

Compound 4, intrinsic clearance in microsomes: 27 mL.min-1.g-1
For compound 4 the middle estimate is 1.0-fold (0.02 log units) above the measured one; low and high end bracket the measured number.
By their numbers in this assay, from the lowest: compounds 2, 4 and 3 (each within the scatter of the next). At a limit, below all of these: compound 1.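

In this assay, a hydrogen-bond donor on a five-membered ring joined to a six-membered aromatic ring of carbon only does not separate this position's aromatic groups: a 1.4-fold higher number from compound 2 to compound 4 (0.13 log units; within the scatter), and a 1.4-fold lower number from compound 3 to compound 4 (0.16 log units; within the scatter). Against bromo, an at least 1.9-fold higher number from compound 1 to compound 4 (0.28 log units; that floor lies within the scatter), so compound 4, unlike compound 3, has no step from compound 1 that is shown to lie beyond the scatter. Compound 1 gives only a limit, so this step is a floor: the limit of < 14 mL.min-1.g-1 in this assay, at which 1 of the 4 values shown sits.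

From the compounds shown here alone, the true distance of compound 4 from compound 1 remains open. Also open, going by these compounds, is whether an amine or a carboxylic acid on the aromatic group at this position would shift the number beyond the scatter from compound 2, compound 3 and compound 4.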